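A Phenyl Group Replaces a Four-Membered Ring Substituent

This account rests on a few compounds, and the source may have more. Where it says the series, first, only, none or still open, it means among the compounds named here.

For the measured compounds named here, in a functional assay on the whole organism (strain albino) with Mus musculus as the target, with a stated time of 0.5 h (a lower number here means that less compound is needed, a higher number that more compound is needed for the effect), compound 1 (`CC(=O)N1N=C(Nc2nc3ccc(C)cc3s2)CC1c1ccc(O)cc1`) gives 54.3 umol/kg and provides the only number in this small set. Compound 2 (`CC(=O)N1N=C(Nc2nc3ccccc3s2)CC1c1ccccc1`) is reported as "not determined" (no result reported) and has no number. Compound 3 (`CC(=O)N1N=C(Nc2nc3ccc(C)cc3s2)CC1OC1=CC=C1`) is likewise reported as "not determined" (no result reported) and so has no place on the numerical scale, which leaves no value from which to measure a step. The next compound to be tested is compound 4 (`CC(=O)N1N=C(Nc2nc3ccc(C)cc3s2)CC1c1ccccc1`). The structural change is a group of 6 heavy atoms (6 carbon; one six-membered aromatic ring of carbon only) in place of a group of 5 heavy atoms (4 carbon, 1 oxygen; one four-membered non-aromatic ring of carbon only), on a saturated ring carbon and it puts phenyl on a saturated ring carbon of the five-membered non-aromatic ring with 2 nitrogen. Going by the values given here, with no value for compound 3, the only anchor is compound 1 at 54.3 umol/kg and no shift beyond the usual scatter from that figure is expected, in either direction. This is a weak basis, resting on a single measured compound. Compound 4 is therefore estimated at 60 umol/kg (expected range 25 umol/kg to 150 umol/kg).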

Compound 4, dose for half-maximal effect: 112 umol/kg
Beside the measured number, compound 4's estimate is 1.9-fold (0.27 log units) below it; measured number inside the range.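

With phenyl on the saturated ring carbon, hydrogen in place of hydroxy on an aromatic carbon gives a 2.1-fold higher number from compound 1 to compound 4 (0.31 log units; beyond the scatter) in this assay, so more compound is needed for the effect once the hydroxy is gone. For the compounds shown here, this is the first readable step in the set: it is modest, but it lies beyond the scatter and shows that this single change to the aromatic ring alters the dose. No measured evidence bears on why the number moves.

Steps involving compound 2 or compound 3 cannot be read, so the four-membered ring group cannot be ranked against phenyl. The compounds shown also leave open how a methoxy group, an amine or a carboxylic acid would compare with the hydroxy of compound 1 on that aromatic carbon.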